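The source may report more compounds than this note shows. Statements on the series, on what has been measured and on what is new or still open speak of the compounds shown alone.

Working notes on the series. Compound 1 `COc1cccc(S(=O)(=O)c2cnc3ccc(Cl)cc3c2N2CCC(C)CC2)c1` gives 87% in an assay on isolated protein for displacement of a labelled ligand from metabotropic glutamate receptor 5 (Homo sapiens), with a stated time of 60 min, tested at 1 uM; a lower number here means less inhibition, a higher number more inhibition at the concentration tested (going by the name of the read-out); it stands second highest of the three numbers measured there. Compound 2 `COc1cccc(S(=O)(=O)c2cnc3ccc(F)cc3c2N2CCC(C)CC2)c1` gives 90%, and the step of a number 3 percentage points higher from compound 1 to compound 2 (within the scatter) is within the scatter. Compound 3 `COc1cccc(S(=O)(=O)c2cnc3ccc(OC)cc3c2N2CCC(C)CC2)c1` gives 0%, so the step of a number 87 percentage points lower from compound 1 to compound 3 (beyond the scatter) is large, as is a number 90 percentage points lower from compound 2 to compound 3 (beyond the scatter).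

Compound 4 `CC1CCN(c2c(S(=O)(=O)c3cccc(F)c3)cnc3ccc(Cl)cc23)CC1` differs from compound 1 by fluoro in place of methoxy on an aromatic carbon of a six-membered aromatic ring of carbon only, meta to a large group; read one bond further out, 3-methoxyphenyl becomes 3-fluorophenyl.

Going by the values given here, none of the measured steps touches the methoxy that leaves here; all three concern a chloro, fluoro or methoxy elsewhere in the shared core. Among the compounds with values here, the only guidance is indirect: a number 3 percentage points higher from compound 1 to compound 2 (within the scatter) shows a halogen swap leaving the read-out unchanged, while a number 87 percentage points lower from compound 1 to compound 3 (beyond the scatter) and a number 90 percentage points lower from compound 2 to compound 3 (beyond the scatter) show that the read-out can collapse when a methoxy enters at a different position. For compound 4 the expectation is therefore a small step, a number 9 percentage points lower from compound 1 to compound 4 (within the scatter), with wide uncertainty. The estimate for compound 4 is 78%, in the range 50% to 95%.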

Compound 4, a percentage reported as inhibition, at one concentration (the size of the read-out at that concentration, not a potency): 58%
For compound 4 the middle estimate is 20 percentage points above the measured one, and the stated range covers the measured number.
By their numbers in this assay, from the lowest: compound 3; then compound 4; then compounds 1 and 2 (each within the scatter of the next).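

In this assay, going by these compounds alone, the first reading at the 3-methoxyphenyl group is a number 29 percentage points lower from compound 1 to compound 4 (beyond the scatter), so this place responds to the change from methoxy to fluoro, with the methoxy compound giving the higher number. The earlier compounds shown here showed only that methoxy in place of fluoro elsewhere in the shared core removes the read-out. The same exchange therefore does not carry one direction across the two places, and its effect on this assay depends on where it is made: the same change on two cores in this assay, a number 90 percentage points lower (beyond the scatter) from compound 2 to compound 3 and a number 29 percentage points higher (beyond the scatter) from compound 4 to compound 1, 119 percentage points apart, beyond the scatter of two such steps

The compounds shown leave open whether the methoxy itself matters here or whether an ethoxy, a hydroxyl or an amine at this place would serve as well. They also leave open whether the fall with fluoro holds for other substituents on the shared core, since only the chloro core is read at this place.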